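Cytotoxicity notes on the series, compound 4 pending

The source may report more compounds than this note shows. Statements on the series, on what has been measured and on what is new or still open speak of the compounds shown alone.

compound 1 `C=Cc1cccc(C(=O)N2CCCC(C(=O)Nc3ccc(Cl)cc3)C2)c1`: 0%
compound 2 `O=C(Nc1cccc(Oc2ccccc2)c1)C1CCCN(C(=O)c2cc(C(F)(F)F)cc(C(F)(F)F)c2)C1`: 1%
compound 3 `COC(=O)c1cc(-c2cccc(NC(=O)C3CCCN(C(=O)c4cc(C(F)(F)F)cc(C(F)(F)F)c4)C3)c2)co1`: 0%

In an ADME assay on PC-3 cells (Homo sapiens) for cytotoxicity, read by WST assay, tested at 100 uM (a lower number here means less inhibition, a higher number more inhibition at the concentration tested (going by the name of the read-out)), compound 1 gives 0%, level with compound 3 at the digits shown and, together with compound 3, the lowest of the three numbers; compound 2 stands a single point away, within the scatter. Among the measured compounds shown here, the one measured step, a number 1 percentage points lower from compound 2 to compound 3 (within the scatter), is also within the scatter, so every measured value sits at the floor of the read-out.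

Compound 4 `CCN(CC)S(=O)(=O)c1cccc(C(=O)N2CCCC(C(=O)Nc3ccc(Cl)cc3)C2)c1` differs from compound 1 by diethylsulfamoyl in place of vinyl on an aromatic carbon. For the measured compounds named here, no measured step exchanges a vinyl group, and the single measured step concerns a different position, so there is no direct precedent for this change. Because compound 1 reads 0% and all measured values lie within the scatter of one another, the expected step is a number 2 percentage points higher from compound 1 to compound 4 (within the scatter), nothing beyond the scatter. Compound 4 is therefore estimated at 2%, with a range from 0% to 15%.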

Compound 4, a percentage reported as inhibition, at one concentration (the size of the read-out at that concentration, not a potency): 0%
Compound 4: the middle estimate sits 2 percentage points above what was measured; measured number inside the range.
By their numbers in this assay, from the lowest: compounds 1, 3, 4 and 2 (each within the scatter of the next).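

In this assay the step is no change at the digits printed from compound 1 to compound 4 (within the scatter) with diethylsulfamoyl in place of vinyl on this aromatic carbon, meta to a large group. Of the compounds shown, this is the only exchange at this position, and the reading stays at the floor of the scale despite the added heavy atoms and hydrogen-bond acceptors of the entering group. As far as these compounds go, whether an amine or a carboxylic acid on this carbon would lift the reading off that floor stays open, as does any effect of the chlorine on the anilide ring. Nothing available explains the flat reading.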